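The compounds below may be only part of what the source reports. "The series", "measured", "known", "first", "only" and "open" are said of these compounds alone.

Measured in a functional assay on MV4-11 cells (Homo sapiens) for inhibition, read by resazurin assay, with a stated time of 72 h; on this read-out higher numbers stand for weaker inhibition of growth and lower numbers for stronger inhibition of growth:
Compound 1 `O=C1NCCC12CCN(c1c(Cl)cncc1-c1ccco1)CC2`: 940 nM
Compound 2 `O=C1NCCC12CCN(c1c(Cl)cncc1-c1cc[nH]c1)CC2`: 1050 nM
Compound 3 `CCOCOCc1ccc(-c2cncc(Cl)c2N2CCC3(CCNC3=O)CC2)o1`: 2970 nM

Compound 2, at 1050 nM, stands within the scatter of compound 1, and compound 3 gives the highest number of the three. Compound 4 `Cc1csc(-c2cncc(Cl)c2N2CCC3(CCNC3=O)CC2)c1` has 4-methylthiophen-2-yl in place of 1H-pyrrol-3-yl on an aromatic carbon. Within the data shown here, the closest precedent is the exchange of furan-2-yl for 1H-pyrrol-3-yl, a 1.1-fold higher number from compound 1 to compound 2 (0.05 log units; within the scatter). The addition of (ethoxymethoxy)methyl, a 3.2-fold higher number from compound 1 to compound 3 (0.50 log units; beyond the scatter), is a modest step and a much less direct guide. In this assay, no step beyond the scatter is therefore expected, in either direction. The expected step is a 1.1-fold lower number from compound 2 to compound 4 (0.02 log units; within the scatter). For compound 4 the estimate is 1000 nM, with an expected range of 400 nM to 2500 nM.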

Compound 4, concentration for 50% growth inhibition: 650 nM
Compound 4: the middle estimate sits 1.5-fold (0.19 log units) above what was measured, within the range that was stated.
By their numbers in this assay, from the lowest: compounds 4, 1 and 2 (each within the scatter of the next); then compound 3.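

In this assay the place on the six-membered aromatic ring, ortho to a large group, accepts a third five-membered aromatic ring with no step beyond the scatter: a 1.6-fold lower number from compound 2 to compound 4 (0.21 log units; within the scatter) and a 1.4-fold lower number from compound 1 to compound 4 (0.16 log units; within the scatter). The first of these steps also gives up the hydrogen-bond donor of 1H-pyrrol-3-yl and brings in sulfur and a methyl group, yet stays within the scatter. Nothing measured here accounts for this. The compounds shown leave open whether an amine or a carboxylic acid in this place would also stay within the scatter.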